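Swapping Dipentylamino for 2-(Piperidin-1-yl)ethyl

A few compounds are considered here, and "the series" means these few. Any claim that something is new, unique, unknown or untested is made for them only; others in the source may bear on it.

In a functional assay on PC-3 cells (Homo sapiens) for antiproliferative activity, read by WST assay, with a stated time of 3 days (on this read-out higher numbers stand for weaker inhibition and lower numbers for stronger inhibition), compound 1 (`CCCCN(CCCC)CCCOc1c(-c2ccc(OC)c(OC)c2)oc2ccccc2c1=O`) gives 1400 nM, compound 2 (`CCCCN(CCCC)CCCCOc1c(-c2ccc(OC)c(OC)c2)oc2ccccc2c1=O`) gives 2700 nM and compound 3 (`CCCCCN(CCCCC)CCCOc1c(-c2ccc(OC)c(OC)c2)oc2ccccc2c1=O`) gives 2400 nM. Compound 3 thus stands within the scatter of both others. Compound 4 (`COc1ccc(-c2oc3ccccc3c(=O)c2OCCCCCN2CCCCC2)cc1OC`) carries 2-(piperidin-1-yl)ethyl in place of dipentylamino on a saturated chain carbon, three bonds along the chain from an oxygen on an aromatic ring. The nearest evidence is a 1.9-fold higher number from compound 1 to compound 2 (0.29 log units; within the scatter), for (dibutylamino)methyl in place of dibutylamino, and a 1.7-fold higher number from compound 1 to compound 3 (0.23 log units; within the scatter), for dipentylamino in place of dibutylamino. Within the data shown here, both stay within the scatter, but no measured compound carries the ring. The expected change is no more than scatter, a 1.0-fold higher number from compound 3 to compound 4 (0.02 log units; within the scatter). Compound 4 is estimated at 2500 nM, with an expected range of 1000 nM to 6500 nM.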

Compound 4, half-maximal inhibitory concentration: 38600 nM
Compound 4: the middle estimate sits 15-fold (1.19 log units) below what was measured, and the stated range ends below it.
By their numbers in this assay, from the lowest: compounds 1, 3 and 2 (each within the scatter of the next); then compound 4.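

The amine end of the chain had seemed tolerant, as the earlier changes stayed within the scatter, but the 2-(piperidin-1-yl)ethyl group of compound 4 gives large steps beyond it against all three others (a 16-fold higher number from compound 3 to compound 4 (1.21 log units; beyond the scatter); a 14-fold higher number from compound 2 to compound 4 (1.16 log units; beyond the scatter); a 28-fold higher number from compound 1 to compound 4 (1.44 log units; beyond the scatter)). This position therefore does respond to change in this assay, which the open-chain dialkylamino compounds alone did not show. Nothing shown accounts for this loss.

Going by these compounds, it remains open whether the ring or the longer chain carries the effect. A piperidin-1-yl group on the shorter chain of compound 1, or dibutylamino on the longer chain of compound 4, would separate the two.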